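The compounds below may be only part of what the source reports. "The series", "measured", "known", "first", "only" and "open" are said of these compounds alone.

Compounds measured in a functional assay on CHO cells for agonist activity at Free fatty acid receptor 1 (Homo sapiens), read by calcium flux; on this read-out higher numbers stand for an effect only at larger amounts of compound and lower numbers for an effect already at smaller amounts:
compound 1, `O=C(O)CCc1nnc(C(=O)Nc2cccc(-c3cccc(Cl)c3)c2)s1` — 1690 nM
compound 2, `O=C(O)CCc1nnc(C(=O)Nc2cccc(-c3ccco3)c2)s1` — 1640 nM
compound 3, `O=C(O)CCc1ccc(OCc2nnc(C(=O)Nc3ccccc3F)s2)cc1` — 580 nM

Compound 3 gives the lowest of the three numbers in this assay; compound 2 stands nearest to it and compound 1 furthest, both beyond the scatter. Going by the values given here, the one step among the measured compounds, a 1.0-fold lower number from compound 1 to compound 2 (0.01 log units; within the scatter), concerns a different part of the molecule than the change now followed and tells little about it.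

Compound 4, `O=C(O)CCc1ccc(OCc2nnc(C(=O)Nc3ccc(F)cc3)s2)cc1`, differs from compound 3 only in 4-fluorophenyl in place of 2-fluorophenyl on an amide-type nitrogen. Among the compounds with values here, no measured pair shows what moving the fluorine on this ring does, so there is no step to lean on. The prior expectation is that the step of a 1.0-fold higher number from compound 3 to compound 4 (0.01 log units; within the scatter) stays within the scatter, with wide uncertainty in either direction.

Compound 4 is therefore estimated at 600 nM in this assay. For compound 4 the estimated range is expected to run from 250 nM to 1500 nM.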

Compound 4, half-maximal effective concentration: 6640 nM
The estimate for compound 4 lay 11-fold (1.04 log units) below the measured number, and the stated range ends below it.
By their numbers in this assay, from the lowest: compound 3; then compounds 2 and 1 (each within the scatter of the next); then compound 4.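

Moving the fluorine on the amide-type nitrogen's ring, with 4-fluorophenyl in place of 2-fluorophenyl, gives an 11-fold higher number from compound 3 to compound 4 (1.06 log units; beyond the scatter) in this assay, although the two groups hold the same atoms. Going by these compounds alone, the earlier compounds offered no pair that changed this ring, and their single step concerned another part of the molecule, so this is the first sign that the read-out depends strongly on where the fluorine sits on this ring. Nothing in the material at hand accounts for the size of this step.

The compounds shown leave open whether a plain phenyl on the same nitrogen would fall nearer to compound 3 or to compound 4, and so whether the 2-fluorophenyl or the 4-fluorophenyl is the one that departs from it. A 2-chlorophenyl or 2-methoxyphenyl at this place would show whether the low number of compound 3 is tied to fluorine itself.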